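A few compounds are considered here, and "the series" means these few. Any claim that something is new, unique, unknown or untested is made for them only; others in the source may bear on it.

Of the compounds shown here, two sharing a core have been measured in a functional assay on the whole organism (strain BALB/c) for inhibition, with Mus musculus as the target, read by paw edema, with a stated time of 4 h, at a dose of 50 mg/kg by the oral route; a lower number here means less inhibition, a higher number more inhibition at the dose given (going by the name of the read-out). Compound 1 `CCNc1nnc(-c2cc(-c3ccc(F)cc3F)ccc2O)s1` gives 50.2% in this assay. Compound 2 `COc1ccc(Nc2nnc(-c3cc(-c4ccc(F)cc4F)ccc3O)o2)cc1` gives 35.3% in this assay, the lower of the two numbers; compound 1 stands higher by a margin beyond the usual scatter. The unmeasured compound 3 `CNc1nnc(-c2cc(-c3ccc(F)cc3F)ccc2O)o1` differs from compound 2 in one place: methyl in place of 4-methoxyphenyl on a nitrogen on an aromatic ring, so that (4-methoxyphenyl)amino becomes methylamino. For the measured compounds named here, no step between measured compounds that differ in only one place is known, so the size of this change can only be judged loosely. Compound 1, which carries an ethyl group on its ring nitrogen rather than a 4-methoxyphenyl, gives the higher number, though it also differs from compound 2 in its core, so the comparison is indirect. Compound 3 is therefore expected to move upward from compound 2 by an estimated a number 8.7 percentage points higher from compound 2 to compound 3 (within the scatter), a step of modest size. Compound 3 is estimated at 44%, with a range from 30% to 58%.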

Compound 3, a percentage reported as inhibition, in the whole organism at one dose (the size of the read-out at that dose, not a potency): 41.4%
Compound 3: middle estimate off by 2.6 percentage points, on the high side, and the stated range covers the measured number.
By their numbers in this assay, from the lowest: compounds 2, 3 and 1 (each within the scatter of the next, the first and the last beyond it).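

For the compounds shown here, compounds 2 and 3 give the first reading of this position alone, since the earlier pair differed in more than one place. In this assay, methyl in place of 4-methoxyphenyl on the nitrogen gives a number 6.1 percentage points higher from compound 2 to compound 3 (within the scatter). This exchange removes the six-membered aromatic ring and leaves 1 heavy atom where there were 8, yet the two compounds cannot be told apart at this dose. Nothing measured here speaks to what lies behind this step.

From the compounds shown here alone, what a longer chain, such as butyl, or a plain amino group on this nitrogen would give remains open, as does a chain carrying a carboxylic acid. Also open, going by these compounds, is whether the same exchange would read alike on the core of compound 1.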